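A Salicylanilide Pair: Nitrile Swapped for Trifluoromethoxy

This account rests on a few compounds, and the source may have more. Where it says the series, first, only, none or still open, it means among the compounds named here.

Two measured members of this small salicylanilide series set the frame. Compound 1 `N#Cc1ccc(NC(=O)c2ccc(Br)cc2O)c(Cl)c1` gives 1860 nM in a functional assay on NALM-6 cells (Homo sapiens) for cytotoxicity, read by luminescence and CellTiter-Glo, with a stated time of 3 days (a higher number here means a weaker inhibitor, a lower number a stronger inhibitor), and compound 2 `O=C(Nc1ccc(C(F)(F)F)cc1)c1cc(F)ccc1O` gives 2090 nM in this assay; these two numbers sit within the usual scatter of one another. From the compounds shown here alone, compound 3 `N#Cc1cccc(NC(=O)c2cc(F)ccc2O)c1` was submitted to this assay but its entry reads "not determined" (no result reported), so compound 3 stands without a number of its own, and its place relative to compound 1 and compound 2 is unknown.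

Compound 4 `O=C(Nc1cccc(OC(F)(F)F)c1)c1cc(F)ccc1O` differs from compound 3 in one place: trifluoromethoxy in place of cyano on an aromatic carbon. The change sits on the aromatic carbon meta to a large group.

Going by the values given here, no measured step exists for this change. Compound 2, which also carries a fluorinated group on the anilide ring, gives 2090 nM, and that is the closest guide available. The expectation is therefore a value near the two measured compounds, with no step beyond the scatter predicted in either direction. Compound 4 is estimated at 2500 nM, with a range from 800 nM to 8000 nM.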

Compound 4, half-maximal inhibitory concentration: 1370 nM
Compound 4: the middle estimate sits 1.8-fold (0.26 log units) above what was measured; measured number inside the range.
By their numbers in this assay, from the lowest: compounds 4, 1 and 2 (each within the scatter of the next).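

Going by these compounds alone, compound 3 carries no number in this assay and compound 4 gives 1370 nM there, and no step between these two can be read. No evidence shown here bears on this result. From the compounds shown here alone, whether trifluoromethoxy in place of cyano changes the cytotoxicity at all remains open.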